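A few compounds are considered here, and "the series" means these few. Any claim that something is new, unique, unknown or untested is made for them only; others in the source may bear on it.

Compound 1, with the structure `COc1nc(Nc2ccccc2)c2ncn([C@@H]3O[C@H](CO)[C@@H](O)[C@H]3O)c2n1`, carries a methoxy group on the shared core and an anilino group on the same ring system. In an ADME assay on L6 cells (Rattus norvegicus) for cytotoxicity (on this read-out lower numbers stand for stronger inhibition and higher numbers for weaker inhibition), compound 1 gives "not determined" (no result reported), so no single number places it on this scale. Compound 3, `COc1nc(NCc2cccc(I)c2)c2ncn([C@@H]3O[C@H](CO)[C@@H](O)[C@H]3O)c2n1`, likewise gives "not determined" (no result reported) in this assay, a second entry without a number. The only measured point comes from compound 2, `COc1nc(NC2CCCC2)c2ncn([C@@H]3O[C@H](CO)[C@@H](O)[C@H]3O)c2n1`, which in this assay gives 51600 nM, a weak reading on the cytotoxicity read-out.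

Compound 4, `OC[C@H]1O[C@@H](n2cnc3c(Nc4ccccc4)nc(NCCOCc4ccccc4)nc32)[C@H](O)[C@@H]1O`, differs from compound 1 in one place: (2-(benzyloxy)ethyl)amino in place of methoxy on an aromatic carbon. The change puts a far larger and more flexible substituent where the small methoxy group stood. Going by the values given here, no measured pair shows what such a change does in this assay, and no step to compound 4 can be computed from the data. Among the compounds with values here, the one number in hand, from compound 2, suggests that this series of nucleoside analogues sits in the weakly cytotoxic region, and there is no basis for expecting compound 4 to move far from it; any shift in this assay is expected to stay within a modest range, in either direction, and possibly not beyond the scatter.

Compound 4 is therefore estimated to give 40000 nM in this assay, with an expected range from 10000 nM to 160000 nM.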

Compound 4, half-maximal inhibitory concentration: 53800 nM
The estimate for compound 4 lay 1.3-fold (0.13 log units) below the measured number; the measured number falls inside the stated range.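

Going by these compounds alone, compound 4 gives 53800 nM in this assay but compound 1 gives "not determined" (no result reported) and so no step between these two compounds can be read. The compounds shown leave open what replacing methoxy with (2-(benzyloxy)ethyl)amino does on this read-out. Nothing shown offers an explanation for the reading of compound 4.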